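Changing the aryl tail on a shared quinoline-free core's fused ring

This account rests on a few compounds, and the source may have more. Where it says the series, first, only, none or still open, it means among the compounds named here.

Measured so far in an ADME assay on HepG2 cells (Homo sapiens) for cytotoxicity, read by luminescence, CellTiter-Glo and ATP content, with a stated time of 72 h; on this read-out lower numbers stand for an effect already at smaller amounts and higher numbers for an effect only at larger amounts of compound:
- compound 1 `COc1cccc(CNCCCNc2ccnc3cc(-c4ccc(F)cc4)ccc23)c1O`: 6840 nM
- compound 2 `COc1ccc(Oc2ccc3c(NCCCNCc4cccc(OC)c4O)ccnc3c2)cc1`: 5500 nM
- compound 3 `COc1cccc(CNCCCNc2ccnc3cc(CC(C)C)ccc23)c1O`: 2920 nM

Three compounds share one core and differ only in the group attached to an aromatic carbon of its fused ring system. Compound 3, carrying an isobutyl group there, has the lowest number of the three in this assay; the gap to compound 2 is small, a 1.9-fold lower number from compound 2 to compound 3 (0.27 log units; within the scatter), while the gap to compound 1 is somewhat larger, a 2.3-fold lower number from compound 1 to compound 3 (0.37 log units; beyond the scatter). Compound 1 and compound 2 themselves lie close together, a 1.2-fold lower number from compound 1 to compound 2 (0.09 log units; within the scatter).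

Compound 4 `COc1ccccc1Oc1ccc2c(NCCCNCc3cccc(OC)c3O)ccnc2c1` is the next candidate. The change from compound 3 is 2-methoxyphenoxy in place of isobutyl on an aromatic carbon. For the measured compounds named here, the step that bears on it most directly is the one between compound 2 and compound 3, since compound 2 carries the closely related 4-methoxyphenoxy group: that step was a 1.9-fold lower number from compound 2 to compound 3 (0.27 log units; within the scatter), a small move. Replacing isobutyl with an aryl ether is therefore expected to shift the number back upward in this assay by roughly that amount, a step of about a 1.7-fold higher number from compound 3 to compound 4 (0.23 log units; within the scatter), though it may well stay within the scatter. Compound 4 is thus estimated at 5000 nM, with a plausible range from 2500 nM to 10000 nM.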

Compound 4, half-maximal effective concentration: 11200 nM
Compound 4: the middle estimate sits 2.2-fold (0.35 log units) below what was measured; the measured number lies above the stated range.
By their numbers in this assay, from the lowest: compounds 3, 2, 1 and 4 (each within the scatter of the next, the first and the last beyond it).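

In this assay moving the methoxy group around the phenoxy ring, from the 4-methoxyphenyl of compound 2 to the 2-methoxyphenyl of compound 4, changes no atom count, yet the number moves beyond the scatter (a 2.0-fold higher number from compound 2 to compound 4 (0.31 log units; beyond the scatter)). So at this position the arrangement within the aryl ether matters, not only the presence of such a group. The step from isobutyl to 2-methoxyphenoxy (a 3.8-fold higher number from compound 3 to compound 4 (0.58 log units; beyond the scatter)) is the widest gap in the set, so the larger group with its extra ring does not simply match the 4-methoxyphenoxy group of compound 2, whose own step from compound 3 stayed within the scatter, while compound 4 cannot be told apart from the 4-fluorophenyl compound (a 1.6-fold higher number from compound 1 to compound 4 (0.21 log units; within the scatter)).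

Nothing at hand explains why the place of the methoxy group on that ring should matter. Also open, from the compounds shown here alone, is how a 3-methoxyphenoxy group, an unsubstituted phenoxy group or a morpholine on this aromatic carbon would read in this assay and whether the isobutyl group's low number would hold against them.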